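The source may hold more compounds than are shown below. What is called first, only, known or untested is meant among the compounds shown, and "the series" means these compounds.

Measured compounds:
compound 1, `CCCCCCCCc1cn([C@H]2C[C@H](O)[C@@H](CO)O2)c(=O)[nH]c1=O`, 52 ug/mL
compound 2, `CCc1cn([C@H]2C[C@@H]3OP(=O)(O)OC[C@H]3O2)c(=O)[nH]c1=O`, 60 ug/mL

Two compounds carry numbers in a functional assay on Raji cells (Homo sapiens); on this read-out higher numbers stand for weaker inhibition and lower numbers for stronger inhibition. Compound 1 `CCCCCCCCc1cn([C@H]2C[C@H](O)[C@@H](CO)O2)c(=O)[nH]c1=O` gives 52 ug/mL in this assay. Compound 2 `CCc1cn([C@H]2C[C@@H]3OP(=O)(O)OC[C@H]3O2)c(=O)[nH]c1=O` gives 60 ug/mL in this assay, and its number and that of compound 1 sit within the scatter of each other, so the two cannot be told apart on this read-out. Going by the values given here, no step between compounds that differ in one place has been measured, so nothing is known here about how a single change moves the number.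

Compound 3 `CCCc1cn([C@H]2C[C@@H]3OP(=O)(O)OC[C@H]3O2)c(=O)[nH]c1=O` is the next compound to be measured in this assay. It differs from compound 2 in one place: methyl in place of hydrogen on a saturated chain carbon, two bonds along the chain from an aromatic carbon. The change is small, and the two measured compounds, which differ in far more than this, already land within the scatter of each other. The step from compound 2 to compound 3 is therefore expected to stay within the scatter, in no clear direction, as a 1.1-fold lower number from compound 2 to compound 3 (0.04 log units; within the scatter). On that basis compound 3 is estimated at 55 ug/mL in this assay, with a range from 25 ug/mL to 120 ug/mL.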

Compound 3, concentration for 50% inhibition: > 500 ug/mL
Compound 3: a limit, no number (the forecaster's own chance of this, stated with the estimate: 10%); middle value at least 9.0-fold (0.95 log units) from the limit.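

In this assay, going by these compounds alone, the first single change that can be read shows that this position on the chain is sensitive: methyl in place of hydrogen on a saturated chain carbon, two bonds along the chain from an aromatic carbon, turning ethyl into propyl, gives an at least 8.3-fold higher number from compound 2 to compound 3 (0.92 log units; beyond the scatter). The change enters only one carbon, with no ring, no hydrogen-bond donor or acceptor and no net charge, yet the step lies beyond the scatter, so weaker inhibition follows from this one change on the shared core. Compound 3 gives > 500 ug/mL, and this is a limit of the assay, not a number, so the step fixes a direction and a minimum size only: the limit of > 500 ug/mL in this assay, at which 1 of the 3 values shown sits.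

How much weaker compound 3 really is remains open, as does whether the loss belongs to this one pair alone, since ethyl to propyl is the only step shown on this core. Whether a longer chain, or a hydroxyl or an amine carried on the propyl chain, would stay at the limit or return to a measurable number is also unknown.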